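Cyclopentyl in Place of Isopropyl, Repeated on a Second Core

This account rests on a few compounds, and the source may have more. Where it says the series, first, only, none or still open, it means among the compounds named here.

Compound 1 `Cc1ccccc1-c1nnc(NNC(C)C)s1` gives 54 mg/kg in a functional assay on the whole organism with Mus musculus as the target, with a stated time of 1 h; a lower number here means that less compound is needed, a higher number that more compound is needed for the effect. Compound 2 `Cc1ccccc1-c1nnc(NNC2CCCC2)s1` differs from it by cyclopentyl in place of isopropyl on an amine nitrogen. In this assay compound 2 gives > 100 mg/kg, which is a limit of the assay and not a number, the case described by the limit of > 100 mg/kg in this assay, at which 1 of the 3 values shown sits. Compound 3 `CC(C)NNc1nnc(-c2ccccc2Cl)s1` has a core that differs from that of compound 1 by chloro in place of methyl on an aromatic carbon; in this assay compound 3 gives 50 mg/kg, a step of a 1.1-fold lower number from compound 1 to compound 3 (0.03 log units; within the scatter). Compound 4 `Clc1ccccc1-c1nnc(NNC2CCCC2)s1` has not been measured; it differs from compound 3 by cyclopentyl in place of isopropyl on an amine nitrogen, the same change as that from compound 1 to compound 2, where the step was an at least 1.8-fold higher number from compound 1 to compound 2 (0.26 log units; that floor lies within the scatter). Beside that earlier step, compound 4 is expected to move by a 2.4-fold higher number from compound 3 to compound 4 (0.38 log units; beyond the scatter) in this assay. Compound 4 is therefore estimated at 120 mg/kg, between 60 mg/kg and 250 mg/kg.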

Compound 4, dose for half-maximal effect: > 100 mg/kg
Compound 4: only a limit was reported; the forecaster's own chance of this, stated with the estimate: 60%; the middle value is on the limit's open side.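

In this assay compound 4 sits at a limit of the assay, so cyclopentyl in place of isopropyl on the core of compound 3 can be read only as a floor, an at least 2.0-fold higher number from compound 3 to compound 4 (0.30 log units; that floor lies within the scatter). Both cores therefore give a floor that points to a higher number, but neither floor lies beyond the scatter, and the sizes of the two steps cannot be compared: the same change on two cores in this assay, an at least 1.8-fold higher number (0.26 log units; that floor lies within the scatter) from compound 1 to compound 2 and an at least 2.0-fold higher number (0.30 log units; that floor lies within the scatter) from compound 3 to compound 4; the limit leaves it open whether they differ. The step from compound 2 to compound 4 cannot be read, and how far the change really reaches on either core is not shown: the limit of > 100 mg/kg in this assay, at which 2 of the 4 values shown sit.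

The compounds shown leave open whether a smaller ring such as cyclopropyl, or a longer chain such as n-butyl, on that amine nitrogen would give a readable value on either core. They also leave open how methoxy in place of chloro or methyl would behave.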